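The source may hold more compounds than are shown below. What is called first, only, known or untested is meant among the compounds shown, and "the series" means these compounds.

Of the compounds shown here, two have been measured in a functional assay on ACHN cells (Homo sapiens) for cytotoxicity, read by sulforhodamine B assay, tested at 10 uM; a lower number here means less inhibition, a higher number more inhibition at the concentration tested (going by the name of the read-out). Compound 1, `CC(C)(C)c1ccc(Cn2cc(-c3cn([C@H]4C[C@H](O)[C@@H](CO)O4)c(=O)[nH]c3=O)nn2)cc1`, gives 102% in this assay. Compound 2, `CC(=O)OC[C@H]1O[C@@H](n2cc(-c3cc(C)no3)c(=O)[nH]c2=O)C[C@@H]1OC(C)=O`, gives 96.4% in this assay. Compound 2 thus stands beside compound 1: the gap between the two numbers is within the usual scatter of repeated measurements, so the two compounds are not told apart by these data, and both sit at the top of the scale.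

Compound 3, `CCc1ccc(-c2cc(-c3cn([C@H]4C[C@H](OC(C)=O)[C@@H](COC(C)=O)O4)c(=O)[nH]c3=O)on2)cc1`, has not yet been measured. It differs from compound 2 in one place: 4-ethylphenyl in place of methyl on an aromatic carbon. For the measured compounds named here, no step between measured compounds is available to show what this change does in this assay. With both measured compounds giving numbers that are level with each other in this assay, the change from compound 2 to compound 3 is expected to give a step of a number 4.4 percentage points lower from compound 2 to compound 3 (within the scatter), that is, none beyond the scatter. Compound 3 is therefore estimated at 92% in this assay, with a range from 60% to 105%.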

Compound 3, a percentage reported as inhibition, at one concentration (the size of the read-out at that concentration, not a potency): 92%
For compound 3 middle estimate and measured number coincide at the digits printed, and the stated range covers the measured number.
By their numbers in this assay, from the lowest: compounds 3, 2 and 1 (each within the scatter of the next).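

For the compounds shown here, putting 4-ethylphenyl in place of methyl gives the first step that can be read at this position in this assay: it is a number 4.4 percentage points lower from compound 2 to compound 3 (within the scatter) and so shows no change beyond the usual scatter. The place lies on an aromatic carbon of the five-membered aromatic ring with 1 nitrogen and 1 oxygen, next to the ring nitrogen, and this single step shows that a group of 8 heavy atoms carrying a six-membered aromatic ring of carbon only can stand there in place of a single carbon while compound 3 stays at the top of the scale with the other two compounds. No measurement shown bears on why the number holds through this change.

What the compounds shown leave open is whether any group at this place would bring the number down, for instance an amine, a carboxylic acid or a longer alkyl chain in place of the 4-ethylphenyl. Also open, from the compounds shown here alone, is whether free hydroxyl groups in place of the acetyl esters of compound 3 would leave its number within the scatter, and how the compounds would separate at concentrations lower than the one tested.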